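A Methyl Added to a Compound Already at the Limit

A few compounds are considered here, and "the series" means these few. Any claim that something is new, unique, unknown or untested is made for them only; others in the source may bear on it.

Compound 2 `Cc1[nH]n(-c2nc3ccccc3[nH]2)c(=O)c1Cc1ccc(Cl)cc1` is one of three compounds tested in an assay on isolated protein for inhibition of alpha-ketoglutarate-dependent dioxygenase alkB homolog 3 (Homo sapiens), read by polymerase chain reaction, with a stated time of 1 h; a lower number here means a stronger inhibitor, a higher number a weaker inhibitor. For compound 2 the result is only a limit, > 10000 nM. Compound 1 `COc1ccc(Cc2c(C)[nH]n(-c3nc4ccccc4[nH]3)c2=O)cc1` gives a number, 630 nM. Compound 3 `Cc1[nH]n(-c2nc3ccccc3[nH]2)c(=O)c1Cc1ccc(Cl)cc1Cl` again returns only a limit, > 10000 nM. Two steps lead away from compound 1: an at least 15-fold higher number from compound 1 to compound 2 (1.20 log units; beyond the scatter) and an at least 15-fold higher number from compound 1 to compound 3 (1.20 log units; beyond the scatter). The step that the two limits leave unreadable from compound 2 to compound 3 cannot be sized because both of its compounds sit at the limit of > 10000 nM in this assay, at which 2 of the 3 values shown sit.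

Compound 4 `Cc1ccc2[nH]c(-n3[nH]c(C)c(Cc4ccc(Cl)cc4)c3=O)nc2c1` differs from compound 2 by methyl in place of hydrogen on an aromatic carbon. Going by the values given here, no measured step touches this ring of the shared core; the known steps change only the other aromatic ring, and both compounds carrying a chlorine there, compound 2 and compound 3, stop at the limit. In this assay the step that the limit leaves unreadable from compound 2 to compound 4 is therefore expected, and compound 4 will likely again come back only as a limit. The estimate for compound 4 in this assay is 15000 nM, with a range from 5000 nM to 50000 nM.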

Compound 4, half-maximal inhibitory concentration: 750 nM
The estimate for compound 4 lay 20-fold (1.30 log units) above the measured number; the measured number lies below the stated range.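

In this assay, going by these compounds alone, a single methyl on an aromatic carbon of the six-membered aromatic ring of carbon only gives an at least 13-fold lower number from compound 2 to compound 4 (1.12 log units; beyond the scatter), so this part of the shared core, unchanged in the earlier compounds, can strongly shift the result. The chloro of compound 2 is kept unchanged in the new compound. Compound 4 gives a measured number, 750 nM. A chlorine on the other aromatic ring therefore does not always go with a result at the limit, as compound 2 and compound 3 had suggested. The value of compound 2 is only a limit, so the full size of this step stays unknown: the limit of > 10000 nM in this assay, at which 2 of the 4 values shown sit.

On these data alone, with one group at this position, it remains open whether an ethyl group or an amine there would act like methyl. As far as these compounds go, it is equally open whether the same methyl would change the result for compound 1, which carries methoxy on the other ring.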